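This account rests on a few compounds, and the source may have more. Where it says the series, first, only, none or still open, it means among the compounds named here.

Measured so far in a functional assay on MGC-803 cells (Homo sapiens) for inhibition, read by MTT assay, with a stated time of 72 h; on this read-out higher numbers stand for weaker inhibition and lower numbers for stronger inhibition:
Compound 1 `N#Cc1c(Nc2ccccc2F)nc(SCc2cn(Cc3ccccc3Cl)nn2)nc1-c1ccccc1` gives 7580 nM.
Compound 2 `Cc1ccccc1Nc1nc(SCc2cn(Cc3ccccc3Cl)nn2)nc(-c2ccccc2)c1C#N` gives 7280 nM.
Compound 3 `Cc1ccc(Cn2cc(CSc3nc(Nc4ccccc4C)c(C#N)c(-c4ccccc4)n3)nn2)cc1` gives only a limit, > 64000 nM, not a number.

Compound 3 thus stands at the assay limit (the limit of > 64000 nM in this assay, at which 1 of the 3 values shown sits), with no measured number of its own. Compound 4 `Cc1ccc(Cn2cc(CSc3nc(Nc4ccc(C)cc4)c(C#N)c(-c4ccccc4)n3)nn2)cc1` has the same atoms joined differently: 4-methylphenyl in place of 2-methylphenyl on a nitrogen on an aromatic ring. Going by the values given here, no measured step makes this same change. The step of a 1.0-fold lower number from compound 1 to compound 2 (0.02 log units; within the scatter) touches the same nitrogen-bound ring but swaps a different group, and the step of an at least 8.7-fold higher number from compound 2 to compound 3 (0.94 log units; beyond the scatter) concerns a ring elsewhere in the molecule. There is therefore no ground to expect a shift in this assay beyond the scatter. The expected step is a step that the limit leaves unreadable from compound 3 to compound 4. Compound 4 is estimated at 80000 nM, between 30000 nM and 250000 nM, and is most likely again reported only as a limit.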

Compound 4, half-maximal inhibitory concentration: > 64000 nM
Compound 4: only a limit was reported; the forecaster's own chance of this, stated with the estimate: 80%; the middle value does not contradict the limit.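

Compound 3 and compound 4 both give only a limit, not a number, so no step between them can be read: the limit of > 64000 nM in this assay, at which 2 of the 4 values shown sit.

Going by these compounds, whether (2-methylphenyl)amino and (4-methylphenyl)amino differ at all in this assay stays open.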